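The source may hold more compounds than are shown below. What is called first, only, known or untested is meant among the compounds shown, and "the series" means these compounds.

Of the compounds shown here, three built on closely related cores have been tested in a functional assay on the whole organism with Rattus norvegicus as the target; on this read-out higher numbers stand for an effect only at larger amounts of compound and lower numbers for an effect already at smaller amounts. Compound 1 (`O=C(/C=C1\CCc2ccc(F)cc21)NC1CCCC1`), which has a substituted amide, gives 14 mg/kg. Compound 2 (`NC(=O)/C=C1\CCc2cc(F)c(F)cc21`) gives 13 mg/kg, and compound 3 (`NC(=O)/C=C1\CCc2ccc(Cl)cc21`) gives 27 mg/kg. The number for compound 3 lies within the usual scatter of the number for compound 1. It lies beyond the scatter from compound 2, so compound 3 needs a larger dose than compound 2.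

The next compound is compound 4 (`NC(=O)/C=C1\CCc2ccc(F)cc21`), which has fluoro in place of chloro on an aromatic carbon of compound 3: fluoro in place of chloro on an aromatic carbon. For the measured compounds named here, no measured pair isolates this swap, so the guidance is indirect. Like compound 4, compound 2 has an unsubstituted amide and carries fluoro, and it gives 13 mg/kg. Like compound 4, compound 1 has the same fluoro pattern on its aromatic ring, but with a different amide, and it gives 14 mg/kg. These two values suggest a modest move towards a lower number in this assay, though not one beyond the scatter. The expected change is a 1.5-fold lower number from compound 3 to compound 4 (0.18 log units; within the scatter). For compound 4 the estimated value is 18 mg/kg, with an expected range from 9 mg/kg to 35 mg/kg.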

Compound 4, dose for half-maximal effect: 21 mg/kg
Estimate against measurement, compound 4: 1.2-fold (0.07 log units) below; measured number inside the range.
By their numbers in this assay, from the lowest: compounds 2, 1, 4 and 3 (each within the scatter of the next, the first and the last beyond it).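

In this assay, for the compounds shown here, the earlier compounds offered only indirect hints about this swap, but the direct pair now gives a 1.3-fold lower number from compound 3 to compound 4 (0.11 log units; within the scatter) for fluoro in place of chloro, so the two halogens cannot be told apart on this aromatic carbon, meta to a fused ring and para to a fused ring. The neighbouring comparisons read the same way: the extra fluoro of compound 2 can be exchanged for hydrogen with a 1.6-fold higher number from compound 2 to compound 4 (0.21 log units; within the scatter) as the result, and the cyclopentyl on the amide-type nitrogen of compound 1 can be exchanged for hydrogen with a 1.5-fold higher number from compound 1 to compound 4 (0.18 log units; within the scatter) as the result, so neither group shows a change that stands clear of the usual scatter in this set. No supporting measurement is available to explain why these three single changes stay so small.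

Still open, as far as these compounds go, is whether a quite different group on this aromatic carbon, such as methoxy, nitrile or trifluoromethyl, would move the dose beyond the scatter. From the compounds shown here alone, it is also open whether another substituent on the amide nitrogen, such as methyl, a longer chain or a phenyl ring, would behave as cyclopentyl does.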